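Replacing bromo with nitro on a shared core

The compounds below may be only part of what the source reports. "The series", "measured", "known", "first", "only" and "open" are said of these compounds alone.

Compounds measured in an ADME assay on NIH3T3 cells (Mus musculus) for cytotoxicity, read by XTT assay, with a stated time of 24 h; a higher number here means a weaker inhibitor, a lower number a stronger inhibitor:
Compound 1, `Cc1ccc(C2=NN(c3nc(-c4ccc(Br)cc4)cs3)C(c3ccc(F)cc3)C2)s1`, gives > 500 ug/mL, which is a limit of the assay.
Compound 2, `Fc1ccc(C2CC(c3ccc(Cl)s3)=NN2c2nc(-c3ccc(Br)cc3)cs2)cc1`, gives > 500 ug/mL, also a limit of the assay.
Compound 3, `COc1ccc(-c2csc(N3N=C(c4ccc(C)s4)CC3c3ccc(F)cc3)n2)cc1`, gives 147 ug/mL.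

Compound 2 sits at the limit of > 500 ug/mL in this assay, at which 2 of the 3 values shown sit, so only a limit is known for it. Compound 4, `O=[N+]([O-])c1ccc(-c2csc(N3N=C(c4ccc(Cl)s4)CC3c3ccc(F)cc3)n2)cc1`, differs from compound 2 by nitro in place of bromo on an aromatic carbon. Going by the values given here, two measured steps touch this series: a step that the two limits leave unreadable from compound 1 to compound 2, and an at least 3.4-fold lower number from compound 1 to compound 3 (0.53 log units; beyond the scatter). Only the latter is readable, and it shows that exchanging the bromo for another group can lower the number beyond the scatter. Compound 4 is therefore expected to give 250 ug/mL, within 80 ug/mL to 500 ug/mL. The expected step is an at least 2.0-fold lower number from compound 2 to compound 4 (0.30 log units; that floor lies within the scatter).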

Compound 4, half-maximal inhibitory concentration: > 500 ug/mL
Compound 4 gave a limit, no number (the forecaster's own chance of this, stated with the estimate: 45%); at least 2.0-fold (0.30 log units) between middle value and limit.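

Compound 2 and compound 4 both sit at a limit of the assay, not at a number, so no step can be read between them: the limit of > 500 ug/mL in this assay, at which 3 of the 4 values shown sit. From the compounds shown here alone, whether nitro in place of bromo changes the result in this assay stays open.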